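From 2-fluorobenzyl to 4-fluorobenzyl in compound 1

The source may report more compounds than this note shows. Statements on the series, on what has been measured and on what is new or still open speak of the compounds shown alone.

Measured so far in an ADME assay on HEK293 cells (Homo sapiens) for cytotoxicity, read by MTT assay, with a stated time of 24 h; a lower number here means a stronger inhibitor, a higher number a weaker inhibitor:
- compound 1 `O=C1/C(=C/c2ccccc2F)CN(Cc2cn(Cc3ccccc3F)nn2)C/C1=C\c1ccccc1F` gives 41200 nM
- compound 2 `Cc1ccc(/C=C2\CN(C(=S)SCc3cn(Cc4ccc(F)cc4)nn3)C/C(=C\c3ccc(C)cc3)C2=O)cc1` has the entry "not determined" (no result reported)
- compound 3 `Cc1ccc(/C=C2\CN(Cc3cn(Cc4ccccc4F)nn3)C/C(=C\c3ccc(C)cc3)C2=O)cc1` gives > 100000 nM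

Among the compounds with values here, compound 1 holds the only exact number in this small set. For compound 3, the entry (> 100000 nM) is a limit of the assay and not a number. Compound 4 `O=C1/C(=C/c2ccccc2F)CN(Cc2cn(Cc3ccc(F)cc3)nn2)C/C1=C\c1ccccc1F` has not yet been measured. It differs from compound 1 by 4-fluorophenyl in place of 2-fluorophenyl on a saturated chain carbon bound to an aromatic nitrogen, with 4-fluorophenyl in place of 2-fluorophenyl on a saturated chain carbon bound to an aromatic nitrogen. No measured step covers this change, so no shift beyond the scatter is expected in this assay, and the estimate stays close to compound 1 at 41200 nM for that reason. The expected step is a 1.1-fold higher number from compound 1 to compound 4 (0.04 log units; within the scatter) in size. Compound 4 is expected at 45000 nM, with an estimated range from 18000 nM to 100000 nM.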

Compound 4, half-maximal inhibitory concentration: 46000 nM
Compound 4: the middle estimate sits 1.0-fold (0.01 log units) below what was measured, within the range that was stated.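

In this assay, 4-fluorophenyl in place of 2-fluorophenyl on a saturated chain carbon bound to an aromatic nitrogen gives a 1.1-fold higher number from compound 1 to compound 4 (0.05 log units; within the scatter). Within the data shown here, this is the first step that can be read at this position, and it shows no shift beyond the scatter for this change. Compound 3 offers no such reading, as its entry is a limit and not a number: the limit of > 100000 nM in this assay, at which 1 of the 4 values shown sits.

The compounds shown leave open whether a group other than fluorobenzyl at this place, such as an unsubstituted benzyl, a longer chain or an amine, would move the number beyond the scatter. They also leave open whether the same change would read alike on the core of compound 3.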